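Swapping a Pyridyl Ring for Cyclopropyl on the Triazole

The source may report more compounds than this note shows. Statements on the series, on what has been measured and on what is new or still open speak of the compounds shown alone.

Of the compounds shown here, three have been tested in a functional assay on the whole organism (strain CF-1) for inhibition, with Mus musculus as the target; on this read-out higher numbers stand for an effect only at larger amounts of compound and lower numbers for an effect already at smaller amounts. Compound 1 `CN(C)Cc1nnc(-c2ccco2)n1-c1ccc(Cl)cc1C(=O)c1ccccc1` gives 16 mg/kg. Compound 2 `Cc1nnc(CN2CCCC2)n1-c1ccc(Cl)cc1C(=O)c1ccccc1Cl` gives 1.8 mg/kg. Compound 3 `CN(C)Cc1nnc(-c2ccncc2)n1-c1ccc(Cl)cc1C(=O)c1ccccc1Cl` gives 11 mg/kg, which places it second highest of the three numbers: the gap to compound 1 lies within the usual scatter, while the gap to compound 2 is clearly beyond it, with compound 2 needing the lower dose.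

The next compound, compound 4 `CN(C)Cc1nnc(C2CC2)n1-c1ccc(Cl)cc1C(=O)c1ccccc1Cl`, differs from compound 3 in one place: cyclopropyl in place of pyridin-4-yl on an aromatic carbon. A flat six-membered aromatic ring with one nitrogen is thus replaced by a small saturated three-membered carbon ring at the position between two ring nitrogen atoms of the shared core. For the measured compounds named here, no measured pair in this set isolates exactly this change, so the expectation rests on comparison alone. Compound 2 carries only a small methyl group at the same position, and its dose is markedly lower than that of compound 3. A small group at this position may therefore be favourable, and a downward step from compound 3 to compound 4 is expected, estimated as a 2.8-fold lower number from compound 3 to compound 4 (0.44 log units; beyond the scatter), because compound 2 gives 1.8 mg/kg. Compound 4 is expected to give 4 mg/kg, with a likely range from 1.5 mg/kg to 12 mg/kg.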

Compound 4, dose for half-maximal effect: 0.6 mg/kg
Compound 4: the middle estimate sits 6.7-fold (0.82 log units) above what was measured; measured number outside the range, below it.
By their numbers in this assay, from the lowest: compound 4; then compound 2; then compounds 3 and 1 (each within the scatter of the next).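

In this assay, replacing pyridin-4-yl with cyclopropyl on the aromatic carbon between two ring nitrogen atoms gives an 18-fold lower number from compound 3 to compound 4 (1.26 log units; beyond the scatter) and this is a large change. For the compounds shown here, it is the first direct sign that this position matters, since none of the earlier compounds formed a pair differing in one place. It also shows that a six-membered aromatic ring with its ring nitrogen is not needed here for an effect at a small dose, and that a three-membered non-aromatic ring of carbon only, without a hydrogen-bond acceptor, gives the lower number, though no supporting measurement explains the drop.

This single swap changes ring size, aromatic character and the ring nitrogen all at once, so the pair cannot show which of these differences accounts for the step. A phenyl ring would keep the six-membered aromatic ring without the nitrogen, while an isopropyl or cyclobutyl group at the same place would show how closely the result depends on the three-membered ring itself.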